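From 4-chlorophenyl to 4-nitrobenzyl in a level series

This account rests on a few compounds, and the source may have more. Where it says the series, first, only, none or still open, it means among the compounds named here.

In a functional assay on HepG2 cells (Homo sapiens) for antiproliferative activity, read by MTT assay (a lower number here means a stronger inhibitor, a higher number a weaker inhibitor), compound 2 `CC1(C)CCc2c(ccc(C(=O)/C=C/c3ccc(OCc4cn(-c5ccc(Cl)cc5)nn4)cc3)c2O)O1` gives 102000 nM. Compound 1 `CCc1ccccc1-n1cc(COc2ccc(/C=C/C(=O)c3cc4c(cc3O)OC(C)(C)CC4)cc2)nn1` gives 115000 nM, and compound 3 `CCCCCCCCn1cc(COc2ccc(/C=C/C(=O)c3cc4c(cc3O)OC(C)(C)CC4)cc2)nn1` gives 127000 nM. These three values lie within the scatter of one another, so compound 2 holds no meaningful rank among them.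

Compound 4 `CC1(C)CCc2c(ccc(C(=O)/C=C/c3ccc(OCc4cn(Cc5ccc([N+](=O)[O-])cc5)nn4)cc3)c2O)O1` keeps the shared core of compound 2 and differs in one group: 4-nitrobenzyl in place of 4-chlorophenyl on an aromatic nitrogen. This places 4-nitrobenzyl in place of 4-chlorophenyl on an aromatic nitrogen of a five-membered aromatic ring with 3 nitrogen.

Among the measured compounds shown here, only one measured step bears on this place. It is a 1.1-fold higher number from compound 1 to compound 3 (0.04 log units; within the scatter), which stays within the scatter. For the measured compounds named here, no measured compound carries 4-nitrobenzyl, so the data offer no direct guide to this group. With that single step as the guide, no change beyond the scatter is expected in this assay, and no direction is favoured.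

The expected change is a 1.1-fold lower number from compound 2 to compound 4 (0.03 log units; within the scatter), which is only an estimate. Compound 4 is estimated at 95000 nM, with an expected range from 45000 nM to 180000 nM.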

Compound 4, half-maximal inhibitory concentration: 69900 nM
Compound 4: the middle estimate sits 1.4-fold (0.13 log units) above what was measured; low and high end bracket the measured number.
By their numbers in this assay, from the lowest: compounds 4, 2, 1 and 3 (each within the scatter of the next).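

In this assay, the change from 4-chlorophenyl to 4-nitrobenzyl gives a 1.5-fold lower number from compound 2 to compound 4 (0.16 log units; within the scatter). The earlier step on this aromatic nitrogen compared only groups of carbon, and this one shows that a group with hydrogen-bond acceptors, which 4-chlorophenyl lacks, also leaves the number within the scatter, so compounds 1, 2, 3 and 4 remain level. No measurement available here explains this result.

From the compounds shown here alone, whether an amine or a carboxylic acid on the benzyl ring, or a short chain such as methyl on the aromatic nitrogen, would move the number beyond the scatter remains open. So does the question of whether plain benzyl would sit level with compound 4, which would separate the nitro group from the change in the group's carbon skeleton.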